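Phenyl in Place of Hydrogen: From Compound 2 to Compound 4

The source may report more compounds than this note shows. Statements on the series, on what has been measured and on what is new or still open speak of the compounds shown alone.

Compound 2 `CC1=NC(C)=C([N+](=O)[O-])C(c2ccccn2)/C1=C(/O)OCCc1ccccc1` gives 639 nM in a functional assay (muscle tissue) with Cavia porcellus as the target (a higher number here means a weaker inhibitor, a lower number a stronger inhibitor), the lowest of the two numbers measured in this set. Compound 1 `CC1=NC(C)=C([N+](=O)[O-])C(c2cccc(C)n2)/C1=C(/O)OC(C)C` gives 25100 nM in this assay, a higher number than compound 2, though the two differ in more than one place. Compound 3 `CC1=NC(C)=C([N+](=O)[O-])C(c2ncccc2C(F)(F)F)/C1=C(/O)OCCc1ccccc1` returns only a limit in this assay, > 59800 nM. The change from compound 2 to compound 3 produced an at least 93-fold higher number from compound 2 to compound 3 (1.97 log units; beyond the scatter), a figure that rests on (the limit of > 59800 nM in this assay, at which 1 of the 3 values shown sits).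

Compound 4 `CC1=NC(C)=C([N+](=O)[O-])C(c2cccc(-c3ccccc3)n2)/C1=C(/O)OCCc1ccccc1` differs from compound 2 by phenyl in place of hydrogen on an aromatic carbon. Within the data shown here, the one measured step that bears on this change, an at least 93-fold higher number from compound 2 to compound 3 (1.97 log units; beyond the scatter), also added a group to the same ring and was large toward a higher number; compound 1, which carries a further group on that ring together with a different ester, likewise sits at 25100 nM. On this evidence the step for compound 4 is expected to be a 31-fold higher number from compound 2 to compound 4 (1.50 log units; beyond the scatter). Compound 4 is therefore estimated at 20000 nM in this assay, within a range from 3000 nM to 80000 nM, with a real chance that only a limit is reported.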

Compound 4, half-maximal inhibitory concentration: 8380 nM
Estimate against measurement, compound 4: 2.4-fold (0.38 log units) above; the measured number falls inside the stated range.
By their numbers in this assay, from the lowest: compound 2; then compound 4; then compound 1. At a limit, above all of these: compound 3.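

In this assay, phenyl in place of hydrogen on the aromatic carbon next to the ring nitrogen brought a 13-fold higher number from compound 2 to compound 4 (1.12 log units; beyond the scatter). Among these compounds, this is the first step on this ring whose size can be read as a number at both ends, whereas the earlier step rests on a limit: the limit of > 59800 nM in this assay, at which 1 of the 4 values shown sits. The new step shows that adding phenyl at this place moves the number upward well beyond the scatter, yet compound 4 still gives a measured value rather than a limit.

Going by these compounds, whether a methoxy group, an amine or a carboxylic acid at this place would land nearer compound 2 or nearer compound 4 remains open. The effect of methyl here also cannot be read alone, as compound 1 carries it together with a different ester.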